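From 4-cyanophenyl to pyridin-3-yl on the shared core

The compounds below may be only part of what the source reports. "The series", "measured", "known", "first", "only" and "open" are said of these compounds alone.

Measured so far:
- compound 1 `CC1(C)C=Cc2c(ccc(C(=O)/C=C/c3ccc(Br)cc3)c2O)O1`: "not determined" (no result reported)
- compound 2 `CC1(C)C=Cc2c(ccc(C(=O)/C=C/c3ccc(C#N)cc3)c2O)O1`: 80200 nM

In an ADME assay on Vero cells (Chlorocebus sabaeus) for cytotoxicity, read by MTT assay, with a stated time of 72 h (a higher number here means that more compound is tolerated, a lower number that less compound is tolerated), compound 2 gives 80200 nM. For the measured compounds named here, this is the only number available, so it cannot yet be ranked against any other compound. Compound 1 offers no comparison, as it has no reported result.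

Compound 3 `CC1(C)C=Cc2c(ccc(C(=O)/C=C/c3cccnc3)c2O)O1` has yet to be measured. It keeps the shared core but carries pyridin-3-yl in place of 4-cyanophenyl on a double-bonded chain carbon bound to a double-bonded chain carbon. Going by the values given here, no pair of measured compounds here shows what a change of this kind does, so the size of the step cannot be read from the data. The sole anchor for an expectation in this assay is compound 2 at 80200 nM, and with nothing to favour either direction, no shift beyond the usual scatter is expected. The expected change is a 1.1-fold lower number from compound 2 to compound 3 (0.06 log units; within the scatter). The estimate for compound 3 is 70000 nM, with an expected range from 25000 nM to 200000 nM.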

Compound 3, half-maximal cytotoxic concentration: 8600 nM
Compound 3: the middle estimate sits 8.1-fold (0.91 log units) above what was measured; measured number outside the range, below it.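

In this assay, for the compounds shown here, the exchange of 4-cyanophenyl for pyridin-3-yl on a double-bonded chain carbon bound to a double-bonded chain carbon gives a 9.3-fold lower number from compound 2 to compound 3 (0.97 log units; beyond the scatter) and so shows, for the first time, that the number in this assay depends on the group held at this place. The change takes away the triple bond and puts a ring with one hetero atom in place of a ring of carbon only, while the counts of hydrogen-bond donors and acceptors and the net charge stay the same on both sides, so those counts alone do not separate compound 2 from compound 3. No measurement at hand bears on why the number falls.

On these data alone, whether the lower number goes with the loss of the nitrile or with the hetero atom in the ring stays open, as this one step carries both changes at once, and a plain phenyl at this place would pull the two apart. Also open, as far as these compounds go, is whether a pyridin-4-yl or a 4-aminophenyl here would stand closer to compound 2 or to compound 3, and whether the step would keep its size on any other core.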